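Aryl group variation on the piperazine nitrogen

This account rests on a few compounds, and the source may have more. Where it says the series, first, only, none or still open, it means among the compounds named here.

Measured so far:
compound 1 `CCC1(CCCCN2CCN(c3ccccc3OC)CC2)C(=O)Nc2ccccc21` — an assay on CHO cells for displacement of a labelled ligand from 5-hydroxytryptamine receptor 7 (Homo sapiens); a lower number here means a stronger inhibitor, a higher number a weaker inhibitor: 5.38 nM
compound 2 `CCC1(CCCCN2CCN(c3ccccc3Cl)CC2)C(=O)Nc2ccccc21` — this assay: 5.11 nM

In this assay compound 2 gives the lowest of the two numbers, yet the step of a 1.1-fold lower number from compound 1 to compound 2 (0.02 log units; within the scatter) lies within the scatter, so compound 1 and compound 2 cannot be ranked. Compound 3 `CCC1(CCCCN2CCN(c3ccc(F)cc3)CC2)C(=O)Nc2ccccc21` carries 4-fluorophenyl in place of 2-chlorophenyl on an amine nitrogen in a ring. Among the compounds with values here, the one measured step, a 1.1-fold lower number from compound 1 to compound 2 (0.02 log units; within the scatter), exchanged chloro for methoxy without a change beyond the scatter; no measured step bears on the shift from 2-chlorophenyl to 4-fluorophenyl, so that part is uncharted. For compound 3 a modest weakening is expected, a 2.3-fold higher number from compound 2 to compound 3 (0.37 log units; beyond the scatter), with wide uncertainty. The estimate for compound 3 is 12 nM, range 3 nM to 50 nM.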

Compound 3, inhibition constant: 0.43 nM
The estimate for compound 3 lay 28-fold (1.45 log units) above the measured number; measured number below the stated range.
By their numbers in this assay, from the lowest: compound 3; then compounds 2 and 1 (each within the scatter of the next).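

Unlike the chloro-for-methoxy exchange, which stayed within the scatter, changing the aryl group on the amine nitrogen in a ring can move the number strongly: this assay shows a 12-fold lower number from compound 2 to compound 3 (1.07 log units; beyond the scatter) and a 13-fold lower number from compound 1 to compound 3 (1.10 log units; beyond the scatter) for 4-fluorophenyl. Two different groups, 2-chlorophenyl and 2-methoxyphenyl, both lie on the weaker side of these steps. Nothing available explains the gain.

Open, from the compounds shown here alone, is whether the fluoro group or its place on the phenyl ring carries the step. 2-Fluorophenyl, 4-chlorophenyl and unsubstituted phenyl would separate these readings.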